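The compounds below may be only part of what the source reports. "The series", "measured", "known", "first", "only" and "open" are said of these compounds alone.

Of the compounds shown here, three sharing one core have been measured in a functional assay on SW1573 cells (Homo sapiens) for antiproliferative activity, read by sulforhodamine B assay, with a stated time of 48 h; on this read-out higher numbers stand for weaker inhibition of growth and lower numbers for stronger inhibition of growth. Compound 1 `Cc1ccc(S(=O)(=O)N2CC[C@@H](Cl)C[C@@H]2c2ccccc2)cc1` gives only a limit there, > 100000 nM. Compound 2 `Cc1ccc(S(=O)(=O)N2CC=C(Cl)CC2)cc1` likewise gives only a limit, > 100000 nM. Among the measured compounds shown here, compound 3 `Cc1ccc(S(=O)(=O)N2CCC(Cl)=CC2CC(C)C)cc1` gives 31000 nM in this assay, and so stands as the only compound with a number rather than a limit. For the measured compounds named here, the single measured step is an at least 3.2-fold lower number from compound 2 to compound 3 (0.50 log units; beyond the scatter), and its size is bounded by the limit of > 100000 nM in this assay, at which 2 of the 3 values shown sit. Compound 4 `Cc1ccc(S(=O)(=O)N2CCC(Cl)=CC2C2CCCCC2)cc1` differs from compound 3 by cyclohexyl in place of isobutyl on a saturated ring carbon. Going by the values given here, no measured step exchanges one carbon group for another at this position; the one step available adds a group where hydrogen stood, and it does not speak to a swap between two such groups. The expected step in this assay is therefore none beyond the scatter: a 1.2-fold lower number from compound 3 to compound 4 (0.09 log units; within the scatter). Compound 4 is accordingly estimated to give 25000 nM, with a range from 8000 nM to 80000 nM.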

Compound 4, concentration for 50% growth inhibition: 62000 nM
Compound 4: the middle estimate sits 2.5-fold (0.39 log units) below what was measured; the range from low to high includes it.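

In this assay, a 2.0-fold higher number from compound 3 to compound 4 (0.30 log units; within the scatter), so this read-out does not separate a cyclohexyl from an isobutyl on this saturated ring carbon next to the ring nitrogen. Among the compounds shown here, a ring of carbon in place of an open chain therefore leaves the number within the usual scatter, a comparison the earlier compounds could not offer. Against hydrogen, the record shows an at least 1.6-fold lower number from compound 2 to compound 4 (0.20 log units; that floor lies within the scatter), but that step starts from a limit rather than a number, and its true size cannot be read: the limit of > 100000 nM in this assay, at which 2 of the 4 values shown sit.

Still open, going by these compounds, is how an amine, a hydroxyl group or a longer chain would read at this carbon in this assay. Compound 1 carries a phenyl group but differs from the others in more than one place, so what that group does here also remains unsettled.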